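Swapping a pyridinyl for a hydroxyphenyl on the side chain

The compounds below may be only part of what the source reports. "The series", "measured", "known", "first", "only" and "open" are said of these compounds alone.

Of the compounds shown here, three sharing one core have been tested in a functional assay on HeLa cells (Homo sapiens) for cytotoxicity, read by WST assay, with a stated time of 48 h; on this read-out lower numbers stand for stronger inhibition and higher numbers for weaker inhibition. Compound 1 `O[C@@H](c1ccccc1)[C@H]1CO[C@H](c2ccccc2)[C@@H](C/C=C/c2ccccn2)C1` gives 33800 nM. Compound 2 `COc1ccc(CCC[C@@H]2C[C@@H]([C@@H](O)c3ccc(OC)c(OC)c3)CO[C@H]2c2ccc(OC)c(OC)c2)cc1OC` gives 35700 nM, and compound 3 `COc1ccc(/C=C/C[C@H]2C[C@H]([C@H](O)c3ccc(OC)c(OC)c3)CO[C@@H]2c2ccc(OC)c(OC)c2)cc1OC` gives 34600 nM. Compound 1 has the smallest of these three numbers, yet its number and those of compound 2 and compound 3 lie within the usual scatter of one another, so none of them can be told apart.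

Compound 4 `Oc1ccccc1/C=C/C[C@H]1C[C@@H]([C@@H](O)c2ccccc2)CO[C@@H]1c1ccccc1` differs from compound 1 in one place: 2-hydroxyphenyl in place of pyridin-2-yl on a double-bonded chain carbon bound to a double-bonded chain carbon. Going by the values given here, with no measured pair showing the effect of such a swap, and with all three known values sitting so close, the step in this assay is expected to be small or none beyond the scatter, in either direction, giving a 1.1-fold lower number from compound 1 to compound 4 (0.05 log units; within the scatter). Compound 4 is therefore estimated at 30000 nM, most likely between 12000 nM and 80000 nM.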

Compound 4, half-maximal inhibitory concentration: 21800 nM
Compound 4: the middle estimate sits 1.4-fold (0.14 log units) above what was measured; low and high end bracket the measured number.
By their numbers in this assay, from the lowest: compounds 4, 1, 3 and 2 (each within the scatter of the next).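

In this assay, this first readable swap at this position, 2-hydroxyphenyl in place of pyridin-2-yl on a double-bonded chain carbon bound to a double-bonded chain carbon, gives a 1.6-fold lower number from compound 1 to compound 4 (0.19 log units; within the scatter). A carbon-only ring bearing a hydrogen-bond donor therefore cannot be told apart from the ring with a hetero atom in this assay. No supporting measurement offers an explanation for this result.

Still open, going by these compounds, is whether a plain phenyl, an aminophenyl or a carboxylic acid at this place would move the number beyond the scatter. On these data alone, whether any group here can do so also remains unknown.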